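The compounds below may be only part of what the source reports. "The series", "measured", "known", "first", "only" and "open" are said of these compounds alone.

Measured in a functional assay on HepG2 cells (Homo sapiens) for antiproliferative activity, read by MTT assay, with a stated time of 48 h; a higher number here means a weaker inhibitor, a lower number a stronger inhibitor:
- compound 1 `O=C(/C=C/c1ccc(Br)cc1)c1nc2ccccc2[nH]1` gives 10900 nM
- compound 2 `O=C(/C=C/c1ccccn1)c1nc2ccccc2[nH]1` gives 340 nM
- compound 3 `O=C(/C=C/c1ccccc1Br)c1nc2ccccc2[nH]1` gives 29200 nM

Compound 2 holds the lowest number of the three, and its gaps to compound 1 and compound 3 both lie beyond the scatter. Compound 4 `O=C(/C=C/c1ccncc1)c1nc2ccccc2[nH]1` remains unmeasured. It carries pyridin-4-yl in place of pyridin-2-yl on a double-bonded chain carbon bound to a double-bonded chain carbon. For the measured compounds named here, no measured pair isolates this change. Compound 1 at 10900 nM and compound 3 at 29200 nM show only that the series spans a wide range in this assay. A moderate weakening, probably beyond the scatter, is expected, and the estimated step is a 3.5-fold higher number from compound 2 to compound 4 (0.55 log units; beyond the scatter). For compound 4 the estimate is 1200 nM, with an expected range from 200 nM to 8000 nM.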

Compound 4, half-maximal inhibitory concentration: 6940 nM
Compound 4: middle estimate off by 5.8-fold (0.76 log units), on the low side; measured number inside the range.
By their numbers in this assay, from the lowest: compound 2; then compounds 4 and 1 (each within the scatter of the next); then compound 3.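

In this assay, pyridin-4-yl in place of pyridin-2-yl on a double-bonded chain carbon bound to a double-bonded chain carbon gives a 20-fold higher number from compound 2 to compound 4 (1.31 log units; beyond the scatter). For the compounds shown here, this is the first single change isolated, and it shows that the site of the ring nitrogen alone, with the atoms and counts unchanged, can produce a large step. Nothing measured explains this step.

Pyridin-3-yl at the same place remains an open case. Also open, as far as these compounds go, is whether a methoxy group or an amine on the pyridin-2-yl ring would preserve the standing of compound 2.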